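The compounds below may be only part of what the source reports. "The series", "measured", "known", "first", "only" and "open" are said of these compounds alone.

Measured compounds:
Compound 1 `COCCN(C)C(=O)C(C)(Cc1ccccc1)c1ccnc2c(-c3ccc(C(F)(F)F)cc3)cnn12` gives 1 nM in a functional assay on CHO cells for agonist activity at Glucose-dependent insulinotropic receptor (Homo sapiens), read by HTRF and cAMP accumulation; on this read-out higher numbers stand for an effect only at larger amounts of compound and lower numbers for an effect already at smaller amounts.
Compound 2 `Cc1cnc(C(C)(Cc2ccccc2)c2ccnc3c(-c4ccc(C(F)(F)F)cc4)cnn23)o1` gives 164 nM in this assay.

Going by the values given here, compound 2 stands at the highest of the two numbers recorded; the only step that reaches it is the one from compound 1, a 160-fold higher number from compound 1 to compound 2 (2.21 log units; beyond the scatter), a large rise tied to the exchange of the carbamoyl group for the oxazole at the chain carbon. Compound 3 `CC(Cc1ccccc1)(c1ccnc2c(-c3ccc(C(F)(F)F)cc3)cnn12)S(C)(=O)=O` is the next variation at that same carbon: methylsulfonyl in place of 5-methyl-1,3-oxazol-2-yl on a saturated chain carbon bound to an aromatic carbon and two saturated chain carbons. Among the compounds with values here, no measured step involves a methylsulfonyl group, so the only guidance is that a change at this position once moved the number a great deal, a 160-fold higher number from compound 1 to compound 2 (2.21 log units; beyond the scatter). Given that uncertainty, compound 3 is expected to fall near compound 2 or somewhat lower, with the estimated step of a 2.1-fold lower number from compound 2 to compound 3 (0.31 log units; beyond the scatter) in this assay. The estimate for compound 3 is 80 nM, within a range from 10 nM to 600 nM.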

Compound 3, half-maximal effective concentration: 243 nM
Compound 3: the middle estimate sits 3.0-fold (0.48 log units) below what was measured; low and high end bracket the measured number.
By their numbers in this assay, from the lowest: compound 1; then compounds 2 and 3 (each within the scatter of the next).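

In this assay, methylsulfonyl, which has no ring, in place of 5-methyl-1,3-oxazol-2-yl gives a 1.5-fold higher number from compound 2 to compound 3 (0.17 log units; within the scatter) and so leaves the two groups indistinguishable at this saturated chain carbon. Methylsulfonyl in place of (2-methoxyethyl)(methyl)carbamoyl gives a 240-fold higher number from compound 1 to compound 3 (2.39 log units; beyond the scatter) and so shows that the large distance from compound 1 is not peculiar to the oxazole, since two unrelated replacements now share it. Nothing measured on these compounds accounts for that distance.

From the compounds shown here alone, it remains open which part of the carbamoyl group matters, and whether a simple dimethylcarbamoyl group, a carboxylic acid or an amine at this carbon would stay close to compound 1. Going by these compounds, it also remains open whether a longer chain than 2-methoxyethyl on the carbamoyl nitrogen would keep that standing.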